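Trading bromine for a cyclopropyloxy group on the shared core

The source may hold more compounds than are shown below. What is called first, only, known or untested is meant among the compounds shown, and "the series" means these compounds.

Of the compounds shown here, three have been tested in an assay on CHO cells with Alpha-2B adrenergic receptor (Homo sapiens) as the target; on this read-out lower numbers stand for smaller maximal responses and higher numbers for larger maximal responses. Compound 1 `CC(C)Oc1ccccc1OC(C)C1=NCCN1` gives 0.5, compound 2 `Cc1cccc(C)c1OC(C)C1=NCCN1` gives 0.8, and compound 3 `CC(Oc1ccccc1Br)C1=NCCN1` gives 0.4, which is the lowest of the three numbers, though its gap to compound 1 is within the scatter. Among the measured compounds shown here, the only single-change step known is a number 0.10 lower from compound 1 to compound 3 (within the scatter). Compound 4 `CC(Oc1ccccc1OC1CC1)C1=NCCN1` arises from compound 3 by cyclopropyloxy in place of bromo on an aromatic carbon. This step runs against the measured one: compound 4 carries an oxygen-linked group where compound 3 carries bromo, much as compound 1 does. Compound 4 is therefore expected to sit close to compound 1, with a number 0.10 higher from compound 3 to compound 4 (within the scatter) as the estimated shift, and the estimated value for compound 4 is 0.5 between 0.3 and 0.7.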

Compound 4, intrinsic activity: the largest response reached, as a fraction of the reference agonist's: 0.6
Estimate against measurement, compound 4: 0.10 below; low and high end bracket the measured number.
By their numbers in this assay, from the lowest: compounds 3, 1 and 4 (each within the scatter of the next, the first and the last beyond it); then compound 2.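

In this assay, among the compounds shown here, the change from bromo to cyclopropyloxy on this aromatic carbon gives a number 0.20 higher from compound 3 to compound 4 (beyond the scatter) and so is the first single change here to pass the scatter. Changing only the group on the oxygen, with cyclopropyl in place of isopropyl, gives a number 0.10 higher from compound 1 to compound 4 (within the scatter) and so does not separate these two oxygen-linked groups. No available evidence bears on the reason for either step.

As far as these compounds go, it remains open whether a smaller methoxy group or a longer butoxy chain on the same oxygen would keep this number. An amine on this aromatic carbon is also untested among the compounds shown here.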